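A Hydroxymethyl Group Takes the Place of a Nitrile

A few compounds are considered here, and "the series" means these few. Any claim that something is new, unique, unknown or untested is made for them only; others in the source may bear on it.

Compound 3 `N#Cc1cccc(C2=NC(c3ccc(F)cc3)(c3ccc(F)cc3)CN2)c1` is the starting point of this step. In an assay on LM cells for displacement of a labelled ligand from Neuropeptide Y receptor type 5 (Homo sapiens) (a lower number here means a stronger inhibitor, a higher number a weaker inhibitor), compound 3 gives 2.7 nM, the lowest number among the three compounds measured. Its nearest neighbour is compound 2 `Fc1ccc(C2(c3ccc(F)cc3)CNC(c3cccc(Cl)c3)=N2)cc1`, for which this assay gives 5.4 nM; the two lie within the scatter of each other, as the step of a 2.0-fold lower number from compound 2 to compound 3 (0.30 log units; within the scatter) shows. Compound 1 `Fc1ccc(C2(c3ccc(F)cc3)CNC(c3ccccc3)=N2)cc1`, the parent bearing hydrogen on that aromatic carbon, gives 32 nM in this assay and stands furthest away, with a 12-fold lower number from compound 1 to compound 3 (1.07 log units; beyond the scatter) between them, while the chloro substitution gave a 5.9-fold lower number from compound 1 to compound 2 (0.77 log units; beyond the scatter).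

Compound 4 `OCc1cccc(C2=NC(c3ccc(F)cc3)(c3ccc(F)cc3)CN2)c1` differs from compound 3 by hydroxymethyl in place of cyano on an aromatic carbon. Among the compounds with values here, no measured step replaces a cyano group with a hydroxymethyl group, so the only guidance is that cyano and chloro both lowered the number relative to hydrogen, while the swap between those two stayed within the scatter. Whether hydroxymethyl keeps that gain is not shown by these data; a modest loss is expected, amounting to a 3.7-fold higher number from compound 3 to compound 4 (0.57 log units; beyond the scatter). Compound 4 is therefore estimated at 10 nM in this assay, within 3 nM to 40 nM.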

Compound 4, half-maximal inhibitory concentration: 59 nM
The estimate for compound 4 lay 5.9-fold (0.77 log units) below the measured number; the whole stated range lies below it.
By their numbers in this assay, from the lowest: compounds 3 and 2 (each within the scatter of the next); then compounds 1 and 4 (each within the scatter of the next).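

Within the data shown here, at this place on the aromatic ring, the earlier compounds showed only gains over hydrogen, whereas the change from 3-cyanophenyl to 3-(hydroxymethyl)phenyl shows that the gain depends on the group: in this assay the result is a 22-fold higher number from compound 3 to compound 4 (1.34 log units; beyond the scatter), and against the chloro compound it is an 11-fold higher number from compound 2 to compound 4 (1.04 log units; beyond the scatter). Set against the parent bearing hydrogen, the result is a 1.8-fold higher number from compound 1 to compound 4 (0.27 log units; within the scatter), so hydroxymethyl keeps none of the gain that cyano and chloro gave and cannot be told apart from hydrogen here. The change also brings in a hydrogen-bond donor, but no measurement in hand connects the loss to that or to anything else.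

The compounds shown leave open how a methoxymethyl group, an aminomethyl group or a carboxylic acid would behave at this place. They also leave open whether the loss belongs to hydroxymethyl alone or extends to a longer chain ending in a hydroxyl.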